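The source may report more compounds than this note shows. Statements on the series, on what has been measured and on what is new or still open speak of the compounds shown alone.

Measured compounds in a functional assay on K562 cells (Homo sapiens) for cytotoxicity, read by sulforhodamine B assay, with a stated time of 48 h; a lower number here means a stronger inhibitor of growth, a higher number a weaker inhibitor of growth:
- compound 1, `ClCc1ccc(Cn2cnc3c(Cl)ncnc32)cc1`: > 100000 nM
- compound 2, `ClCc1ccccc1Cn1cnc2c(Cl)nc(Cl)nc21`: 370 nM
- compound 3, `ClCc1cccc(Cn2cnc3nc(Cl)nc(Cl)c32)c1`: 2690 nM

Compound 1 gives only a limit of the assay in this assay, (the limit of > 100000 nM in this assay, at which 1 of the 3 values shown sits). Of the two numbers that were read, compound 2 stands lowest; compound 3 sits at a higher number, and that gap is beyond the scatter. Going by the values given here, the two dichloro compounds differ only in where the chloromethyl sits on the benzyl ring, so no single-change step between measured compounds is available.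

Compound 4, `Nc1nc(Cl)c2ncn(Cc3ccccc3CCl)c2n1`, has not yet been measured. It differs from compound 2 by amino in place of chloro on an aromatic carbon. Among the compounds with values here, no measured pair shows this exchange, so the size of the step is a guess. Taking compound 2 at 370 nM as the anchor, a moderate loss is expected: the step from compound 2 to compound 4 is estimated at a 3.2-fold higher number from compound 2 to compound 4 (0.51 log units; beyond the scatter). For compound 4 the expected value in this assay is 1200 nM, with a range from 300 nM to 6000 nM.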

Compound 4, concentration for total growth inhibition: > 100000 nM
Compound 4 gave a limit, no number; the forecaster's own chance of this, stated with the estimate: 10%; at least 83-fold (1.92 log units) between middle value and limit.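

In this assay, going by these compounds alone, amino in place of chloro on the aromatic carbon between two ring nitrogen atoms gives an at least 270-fold higher number from compound 2 to compound 4 (2.43 log units; beyond the scatter), the only single-change step, and it is large. This position is therefore not indifferent to the exchange: with the rest of compound 2 unchanged, this single change leaves no readable value. As far as these compounds go, compound 4 gives a limit and not a number, so the true size of the step stays unknown: the limit of > 100000 nM in this assay, at which 2 of the 4 values shown sit.

From the compounds shown here alone, whether the loss follows from the entry of amino or from the departure of chloro remains open; a methoxy or methylamino group at this carbon would help separate the two. Also open, going by these compounds, is whether the exchange has a similar result with the chloromethyl group elsewhere on the benzyl ring.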